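Propyl on the Ring Nitrogen of a Potent Xanthine

The source may report more compounds than this note shows. Statements on the series, on what has been measured and on what is new or still open speak of the compounds shown alone.

Compound 1, with the structure `CCCn1c(=O)[nH]c2nc(-c3ccc(N=C=S)cc3)[nH]c2c1=O`, is a propyl-bearing xanthine carrying an isothiocyanate-substituted phenyl group. In an assay on membranes from CHO cells for displacement of a labelled ligand from adenosine receptor A2b (Homo sapiens), read by radioligand binding, with stated times of 4 h and 0.5 h (a higher number here means a weaker inhibitor, a lower number a stronger inhibitor), compound 1 gives 0.661 nM. Its companion, compound 2 with the structure `CCCn1c(=O)[nH]c2nc(-c3cccc(N=C=S)c3)[nH]c2c1=O`, carries the same isothiocyanate on the phenyl ring at a different position, and in this assay compound 2 gives 2.82 nM. Going by the values given here, of the two numbers known so far, compound 1 holds the lowest, and the gap to compound 2 lies beyond the usual scatter, so compound 1 is the stronger inhibitor of the pair.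

Compound 3, with the structure `CCCn1c(=O)c2[nH]c(-c3ccc(N=C=S)cc3)nc2n(CCC)c1=O`, keeps the core and the phenyl isothiocyanate of compound 1 and differs in one place: propyl in place of hydrogen on an aromatic nitrogen. Among the compounds with values here, no step of this kind has yet been measured here, so its size can only be anticipated. Given that compound 1 already sits at 0.661 nM, a modest step is expected, most likely toward a somewhat lower number or none beyond the scatter. For compound 3 in this assay the expected value is 0.5 nM, within a range of 0.15 nM to 1.8 nM, which amounts to an estimated step of a 1.3-fold lower number from compound 1 to compound 3 (0.12 log units; within the scatter).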

Compound 3, inhibition constant: 3.24 nM
Estimate against measurement, compound 3: 6.5-fold (0.81 log units) below; the whole stated range lies below it.
By their numbers in this assay, from the lowest: compound 1; then compounds 2 and 3 (each within the scatter of the next).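

In this assay, propyl in place of hydrogen on this aromatic nitrogen gives a 4.9-fold higher number from compound 1 to compound 3 (0.69 log units; beyond the scatter), which shows that this position of the shared core responds to substitution, something that compounds 1 and 2, both with hydrogen here, could not show. The change makes the compound a weaker inhibitor, so on the core of compound 1 propyl at this nitrogen brings no gain over hydrogen, although the step is modest and compound 3 still gives a low nanomolar number, 3.24 nM, in this assay. Nothing measured here bears on the cause of this step.

As far as these compounds go, whether the loss follows the length of the chain remains open: a methyl group, a butyl group or a longer chain carrying an amine or a carboxylic acid at this nitrogen could each give a smaller or a larger step than propyl. From the compounds shown here alone, it is also open whether the same change would give a step of similar size with the isothiocyanate placed as in compound 2, since this single step comes from one pair on one core.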